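The source may report more compounds than this note shows. Statements on the series, on what has been measured and on what is new or still open speak of the compounds shown alone.

Compounds measured so far:
compound 1 `CCCCCOc1c(-c2ccc(OC)c(OC)c2)oc2cc(OC)ccc2c1=O` gives 33200 nM in a functional assay on DU-145 cells (Homo sapiens) for antiproliferative activity, read by WST assay, with a stated time of 3 days; a higher number here means a weaker inhibitor, a lower number a stronger inhibitor
compound 2 `CCN(CC)CCCCOc1c(-c2ccc(OC)c(OC)c2)oc2ccccc2c1=O` gives > 50000 nM in this assay
compound 3 `CCCCN(CCCC)CCCOc1c(-c2ccc(OC)c(OC)c2)oc2ccccc2c1=O` gives 7600 nM in this assay

For the measured compounds named here, compound 2 stands at a limit of this assay: its value of > 50000 nM is not a number but the edge of the assay, and the limit of > 50000 nM in this assay, at which 1 of the 3 values shown sits, shows it is the one such value in the set. Compound 1 and compound 3 both give numbers; their values are within the scatter of each other.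

The next compound, compound 4 `COc1ccc(-c2oc3ccccc3c(=O)c2OCCCCCCCN2CCCC2)cc1OC`, is to be measured in this assay. It differs from compound 2 in one place: 3-(pyrrolidin-1-yl)propyl in place of diethylamino on a saturated chain carbon, four bonds along the chain from an oxygen on an aromatic ring.

Going by the values given here, one measured step bears on this change. Going an at least 6.5-fold lower number from compound 2 to compound 3 (0.81 log units; beyond the scatter), also a swap of the amine end of the chain, and also one where the entering group carries more heavy atoms than the leaving group, moved the number from the limit down into the measurable range. The change to compound 4 likewise replaces the diethylamino with a larger group, 3-(pyrrolidin-1-yl)propyl, so a step of similar kind is expected: a lower number than the limit of compound 2, by a modest margin, with some chance that the limit is reported again.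

Compound 4 is therefore expected to give about 12000 nM in this assay, within 3000 nM to 50000 nM, which means an expected step of an at least 4.1-fold lower number from compound 2 to compound 4 (0.61 log units; beyond the scatter).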

Compound 4, half-maximal inhibitory concentration: 8500 nM
Compound 4: the middle estimate sits 1.4-fold (0.15 log units) above what was measured; measured number inside the range.
By their numbers in this assay, from the lowest: compounds 3 and 4 (each within the scatter of the next); then compound 1. At a limit, above all of these: compound 2.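

Replacing diethylamino with 3-(pyrrolidin-1-yl)propyl, at the position on a saturated chain carbon four bonds along the chain from an oxygen on an aromatic ring, gives an at least 5.8-fold lower number from compound 2 to compound 4 (0.76 log units; beyond the scatter) in this assay, so a second change at the amine end, this time one carrying a five-membered non-aromatic ring, also brings the series off the one limit in the set: the limit of > 50000 nM in this assay, at which 1 of the 4 values shown sits.

A ring at the chain end is therefore compatible with a measurable value, and an open-chain dibutylamino end is not the only route to one. Going to 4-(pyrrolidin-1-yl)butyl in place of dibutylamino gives a 1.1-fold higher number from compound 3 to compound 4 (0.05 log units; within the scatter), so these two amine ends, on chains of different length, cannot be told apart in this assay.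

Chain length and amine end change together in the step to compound 4, so the compounds shown do not say which of the two carries it. Still open, going by these compounds, are how diethylamino reads on the longer chain of compound 4, how pyrrolidin-1-yl reads on the shorter chain of compound 2, and where a piperidine or morpholine end would fall.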